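Amine on the propoxy chain: piperidine to pyrrolidine

A few compounds are considered here, and "the series" means these few. Any claim that something is new, unique, unknown or untested is made for them only; others in the source may bear on it.

Measured compounds in a functional assay on MKN-45 cells (Homo sapiens) for cytotoxicity, read by MTT assay, with a stated time of 72 h; a higher number here means a weaker inhibitor, a lower number a stronger inhibitor:
Compound 1 `COc1cccc(-c2cc(C(=O)Nc3ccc(Oc4ccnc5cc(OCCCN6CCCCC6)c(OC)cc45)c(F)c3)c3ccccc3n2)c1` gives 360 nM.
Compound 2 `COc1cc2c(Oc3ccc(NC(=O)c4cc(-c5ccc(F)cc5)nc5ccccc45)cc3F)ccnc2cc1OCCCN1CCCCC1` gives 28 nM.
Compound 3 `COc1cc2c(Oc3ccc(NC(=O)c4cc(-c5ccc(Cl)c(Cl)c5)nc5ccccc45)cc3F)ccnc2cc1OCCCN1CCCCC1` gives 730 nM.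

Compound 1 holds the second highest number of the three. Its nearest neighbour is compound 3, reached by a 2.0-fold higher number from compound 1 to compound 3 (0.31 log units; beyond the scatter); its furthest is compound 2, reached by a 13-fold lower number from compound 1 to compound 2 (1.11 log units; beyond the scatter). The remaining pair is joined by a 26-fold higher number from compound 2 to compound 3 (1.42 log units; beyond the scatter). All three of these steps change only the aryl group attached to the shared core; the amine at the end of the propoxy chain is the same in every measured compound.

Compound 4 `COc1cccc(-c2cc(C(=O)Nc3ccc(Oc4ccnc5cc(OCCCN6CCCC6)c(OC)cc45)c(F)c3)c3ccccc3n2)c1` differs from compound 1 by pyrrolidin-1-yl in place of piperidin-1-yl on a saturated chain carbon, three bonds along the chain from an oxygen on an aromatic ring. No measured step touches this part of the molecule, so nothing among the shown data bears directly on the change; it is read here as a small edit to a chain that is otherwise held constant throughout the series. The expectation for this assay is therefore no step beyond the scatter, no change at the digits printed from compound 1 to compound 4 (within the scatter). Compound 4 is expected at 360 nM, with a range of 150 nM to 900 nM.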

Compound 4, half-maximal inhibitory concentration: 430 nM
Beside the measured number, compound 4's estimate is 1.2-fold (0.08 log units) below it; low and high end bracket the measured number.
By their numbers in this assay, from the lowest: compound 2; then compounds 1, 4 and 3 (each within the scatter of the next, the first and the last beyond it).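

In this assay, replacing piperidin-1-yl with pyrrolidin-1-yl on a saturated chain carbon, three bonds along the chain from an oxygen on an aromatic ring, gives a step within the scatter (a 1.2-fold higher number from compound 1 to compound 4 (0.08 log units; within the scatter)). Among the compounds shown here, this is the first reading at the end of the propoxy chain, and with the 3-methoxyphenyl group held constant, the six-membered and five-membered rings cannot be told apart here, unlike the aryl change that gives a 13-fold lower number from compound 1 to compound 2 (1.11 log units; beyond the scatter) and lies beyond the scatter. No supporting measurement is available to explain the size of this step.

Going by these compounds, the reading covers one aryl group only, so it remains open whether the same ring change would also stay within the scatter on the 4-fluorophenyl group of compound 2 or the 3,4-dichlorophenyl group of compound 3. Also open, on these data alone, is how this position would respond to morpholin-4-yl, 4-methylpiperazin-1-yl or an open-chain dimethylamino group, or to a 4-(piperidin-1-yl)butyl chain in place of 3-(piperidin-1-yl)propyl.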